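A few compounds are considered here, and "the series" means these few. Any claim that something is new, unique, unknown or untested is made for them only; others in the source may bear on it.

Measured compounds:
Compound 1, `C=C1CCCC(C)(C)C1CC[C@]1(C)CC[C@@H]([C@@H](C)C(=O)O)OO1`, gives 2060 nM.
Compound 2, `C=C1CCCC(C)(C)C1CC[C@]1(C)CC[C@H]([C@@H](C)C(=O)OC)OO1`, gives 1600 nM.
Compound 3, `C=C1CCCC(C)(C)C1(O)CC/C(C)=C/CC[C@]1(C)CC[C@@H]([C@@H](C)C(=O)OC)OO1`, gives only a limit, > 5000 nM.

All three numbers come from a functional assay on HL-60 cells (Homo sapiens) for cytotoxicity, read by colony formation; a higher number here means a weaker inhibitor of growth, a lower number a stronger inhibitor of growth. Compound 1 gives the highest of the two numbers that were actually measured; compound 2 is the nearest, and the gap between the two lies within the usual scatter, so the two cannot be told apart. For compound 3 the assay reports only a limit, (the limit of > 5000 nM in this assay, at which 1 of the 3 values shown sits), and not a number.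

The step followed here leads from compound 1 to the unmeasured compound 4, `C=C1CCCC(C)(C)C1CC[C@@]1(C)CC[C@H]([C@@H](C)C(=O)O)OO1`. The two share every atom and bond; the change is the two compounds have the same atoms and bonds; at least one stereo element is drawn with a configuration in one of them and without one in the other: 2 of 4 stereo elements differ; a stereocentre at a saturated ring carbon is drawn R in compound 1 and S in compound 4; a stereocentre at a saturated ring carbon is drawn S in compound 1 and R in compound 4.

For the measured compounds named here, no measured pair here shows what inverting two ring stereocentres does in this assay, so the size of the step is open. The step from compound 1 to compound 4 is expected to be a 1.7-fold higher number from compound 1 to compound 4 (0.23 log units; within the scatter), a modest loss, with a wide range around it. Compound 4 is therefore estimated at 3500 nM, within a range from 1000 nM to 12000 nM.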

Compound 4, concentration for 50% growth inhibition: 1630 nM
Compound 4: middle estimate off by 2.1-fold (0.33 log units), on the high side; measured number inside the range.
By their numbers in this assay, from the lowest: compounds 2, 4 and 1 (each within the scatter of the next). At a limit, above all of these: compound 3.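

For the compounds shown here, this is the first pair in the set that differs only in stereochemistry, and the change gives a 1.3-fold lower number from compound 1 to compound 4 (0.10 log units; within the scatter). In this assay, then, reversing the configuration drawn at these two saturated ring carbons leaves compound 1 and compound 4 indistinguishable, so within this pair growth inhibition does not depend measurably on those two stereocentres. One caution applies to reading the pair as a clean inversion: the fact that one of compounds 1 and 4 is drawn with a defined configuration and the other without, at the place where they differ

Going by these compounds, the two remaining stereo elements are shared by compound 1 and compound 4, so what they contribute stays open. On these data alone, it is equally open whether this insensitivity would hold with an amide or a primary alcohol in place of the carboxylic acid, or with a longer chain carrying that group.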